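The compounds below may be only part of what the source reports. "The series", "measured", "known", "first", "only" and "open" are said of these compounds alone.

Compound 1, with structure `NC1CCC(Nc2nc(NCc3ccc(-c4ccccc4)cc3)c3ncn(C4CCCC4)c3n2)CC1`, has the lowest number of the two measured compounds in a functional assay on HeLa cells (Homo sapiens) for inhibition, with a stated time of 72 h; on this read-out higher numbers stand for weaker inhibition and lower numbers for stronger inhibition: compound 1 gives 240 nM. Compound 2, built as `CC(C)(O)CNc1nc(NCc2ccc(-c3ccco3)nc2)c2ncn(C3CCCC3)c2n1`, gives 667 nM in this assay, a gap from compound 1 that goes beyond the usual scatter of this kind of test. Compound 3, drawn as `Nc1ccccc1CNc1nc(NC2CCC(N)CC2)nc2c1ncn2C1CCCC1`, has not yet been measured. It differs from compound 1 in one place: 2-aminophenyl in place of 4-phenylphenyl on a saturated chain carbon bound to a nitrogen on an aromatic ring. The group that leaves has two six-membered aromatic rings of carbon only and no hydrogen-bond donor or acceptor, while the group that enters has one such ring together with one hydrogen-bond donor and one hydrogen-bond acceptor. Among the measured compounds shown here, no pair of measured compounds shows a change of this kind, so there is no direct guide to its size or direction. The step is expected to be a 1.7-fold higher number from compound 1 to compound 3 (0.22 log units; within the scatter), a modest move toward weaker inhibition that may still fall within the scatter. Compound 3 is therefore estimated at 400 nM, with a range from 130 nM to 1300 nM.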

Compound 3, half-maximal inhibitory concentration: 1030 nM
For compound 3 the middle estimate is 2.6-fold (0.41 log units) below the measured one; measured number inside the range.
By their numbers in this assay, from the lowest: compound 1; then compounds 2 and 3 (each within the scatter of the next).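

Among the compounds shown here, this is the first change whose effect can be read directly. Compound 1 and compound 3 differ only in the group on a saturated chain carbon bound to a nitrogen on an aromatic ring. In this assay, putting 2-aminophenyl in place of 4-phenylphenyl gives (a 4.3-fold higher number from compound 1 to compound 3 (0.63 log units; beyond the scatter)), so inhibition becomes weaker by more than the usual scatter while the rest of the molecule stays the same, and the group at this place clearly matters for this read-out. No measurement here explains the shift.

The change removes one aromatic ring and adds an amine in a single step, so the compounds shown cannot tell which of the two accounts for the weaker inhibition. A plain phenyl group at this place would separate the two parts of the change, and comparing it with 2-hydroxyphenyl or 2-methoxyphenyl would show whether the amine itself matters or whether other groups on the ring give a similar result.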